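The source may report more compounds than this note shows. Statements on the series, on what has been measured and on what is new or still open speak of the compounds shown alone.

Four related compounds were examined in a functional assay on the whole organism for antagonist activity, with Mus musculus as the target; on this read-out higher numbers stand for an effect only at larger amounts of compound and lower numbers for an effect already at smaller amounts. Compound 1 `Cn1c(-c2ccccc2)nnc1[S+](C)[O-]` gives 18.6 mg/kg in this assay. Compound 2 `CC[S+]([O-])c1nnc(-c2ccccc2)n1C` differs from compound 1 by a single change, (methyl in place of hydrogen on a saturated chain carbon bound to a sulfur), and in this assay compound 2 gives 14.4 mg/kg. That change made a 1.3-fold lower number from compound 1 to compound 2 (0.11 log units; within the scatter), so the two numbers cannot be told apart with confidence.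

Compound 3 `CSc1nnc(-c2ccc(Cl)cc2)n1C` rests on a different core, and the difference between the two cores is not broken down here; in this assay compound 3 gives 28.1 mg/kg. Compound 4 `CCn1c(SC)nnc1-c1ccc(Cl)cc1` has not yet been measured. It differs from compound 3 by methyl in place of hydrogen on a saturated chain carbon bound to an aromatic nitrogen. Among the measured compounds shown here, this is the same kind of change as the one from compound 1 to compound 2, but not the same: there the entering methyl sits on a saturated chain carbon bound to a sulfur, here it sits on a saturated chain carbon bound to an aromatic nitrogen. Because the earlier step was a 1.3-fold lower number from compound 1 to compound 2 (0.11 log units; within the scatter), the step from compound 3 to compound 4 is expected to be small as well, a 1.2-fold lower number from compound 3 to compound 4 (0.07 log units; within the scatter). Compound 4 is therefore estimated to give about 24 mg/kg in this assay, most likely between 10 mg/kg and 60 mg/kg.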

Compound 4, dose for half-maximal effect: 26.7 mg/kg
For compound 4 the middle estimate is 1.1-fold (0.05 log units) below the measured one; the range from low to high includes it.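

In this assay adding the methyl gave a 1.1-fold lower number from compound 3 to compound 4 (0.02 log units; within the scatter) and so leaves compound 3 and compound 4 impossible to tell apart. This does not show that the methyl has any effect of its own, and two pairs say nothing about cores beyond these two; nor can they separate the two places, a saturated chain carbon bound to a sulfur and a saturated chain carbon bound to an aromatic nitrogen. What they do show is that this small change gave results on the two cores that cannot be told apart, so for these two pairs its outcome carried over from one core to the other: the same change on two cores in this assay, a 1.3-fold lower number (0.11 log units; within the scatter) from compound 1 to compound 2 and a 1.1-fold lower number (0.02 log units; within the scatter) from compound 3 to compound 4, 1.2-fold (0.09 log units) apart, within the scatter of two such steps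

The compounds shown leave open what a longer chain, such as propyl or butyl, would do at these places. Equally open, from the compounds shown here alone, is what a group of another kind, such as an amine or a carboxylic acid, would do there.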